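Compound 2 and the double inversion leading to compound 3

The source may hold more compounds than are shown below. What is called first, only, known or untested is meant among the compounds shown, and "the series" means these compounds.

In a functional assay on NCI-H460 cells (Homo sapiens) for antiproliferative activity, with a stated time of 72 h (on this read-out lower numbers stand for stronger inhibition and higher numbers for weaker inhibition), compound 1 (`C=CC[C@H]1C[C@]2([C@@H](C)Cc3ccc(OC)c(OC)c3)OCOC2=CC1=O`) gives 260 nM and compound 2 (`C=CC[C@H]1C[C@]2([C@H](C)Cc3ccc(OC)c(OC)c3)OCOC2=CC1=O`) gives 320 nM. Within the data shown here, these two values lie within the scatter of each other, so compound 2 stands level with the only other measured compound.

Compound 3 (`C=CC[C@@H]1C[C@]2([C@@H](C)Cc3ccc(OC)c(OC)c3)OCOC2=CC1=O`) differs from compound 2 as follows: the two compounds have the same atoms and bonds and differ only in configuration as drawn: 2 of 3 stereo elements differ; a stereocentre at a saturated ring carbon is drawn S in compound 2 and R in compound 3; a stereocentre at a saturated chain carbon is drawn R in compound 2 and S in compound 3. Among the measured compounds shown here, the one measured step that bears on this change is a 1.2-fold higher number from compound 1 to compound 2 (0.09 log units; within the scatter). That step concerns only the stereocentre at the saturated chain carbon, and it lies within the scatter. No measured step covers the stereocentre at the saturated ring carbon, and the range is kept wide for that reason. In this assay, a modest move towards a higher number is expected, possibly no larger than the scatter. The expected step is a 1.3-fold higher number from compound 2 to compound 3 (0.12 log units; within the scatter). The estimated value for compound 3 is 420 nM, with an expected range of 130 nM to 1500 nM.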

Compound 3, half-maximal inhibitory concentration: > 4000 nM
Compound 3: no number, only a limit (the forecaster's own chance of this, stated with the estimate: 5%); at least 9.5-fold (0.97 log units) between middle value and limit.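

In this assay compound 3 gives > 4000 nM, which is a limit of the assay and not a number. The stereocentre at the saturated ring carbon, untouched by the earlier pair, carries a large step, an at least 15-fold higher number from compound 1 to compound 3 (1.18 log units; beyond the scatter), against a 1.2-fold higher number from compound 1 to compound 2 (0.09 log units; within the scatter) at the saturated chain carbon, and the two compounds of the large step are separated by configuration alone: the fact that compounds 1 and 3 differ only in the configuration as drawn. With both stereocentres changed the step is also large, an at least 12-fold higher number from compound 2 to compound 3 (1.09 log units; beyond the scatter), so among these compounds the higher number goes with the ring carbon drawn R.

From the compounds shown here alone, the true size of both large steps stays unknown, as only a limit stands for compound 3. Also open, going by these compounds, is whether the ring carbon configuration matters as much with a longer chain or an amine at that stereocentre.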